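Ester trimming on the shared core: compound 1 to compound 4

The compounds below may be only part of what the source reports. "The series", "measured", "known", "first", "only" and "open" are said of these compounds alone.

Of the compounds shown here, three carry numbers so far. Compound 1 `CCCOC(=O)C1=C(C)NC(C)=C(C(=O)OCCC)C1c1csc(-c2ccc(Cl)cc2)n1` stands lowest of the three: in an assay on isolated protein for antagonist activity at Voltage-dependent L-type calcium channel subunit alpha-1C (Cavia porcellus), with a stated time of 15 min (on this read-out lower numbers stand for stronger inhibition and higher numbers for weaker inhibition), compound 1 gives 4800 nM. Compound 3 `CC1=C(C(=O)OCc2ccccc2)C(c2csc(-c3ccc(Cl)cc3)n2)C(C(=O)OCc2ccccc2)=C(C)N1` gives 11000 nM in this assay, a higher number beyond the scatter, and compound 2 `CC1=C(C(=O)OC(C)C)C(c2csc(-c3ccc(Cl)cc3)n2)C(C(=O)OC(C)C)=C(C)N1` gives 37200 nM, the highest of the three. No pair among these differs in a single place, so no single step can be read from them. Compound 4 `CCCOC(=O)C1=C(C)NC(C)=C(C(=O)OC)C1c1csc(-c2ccc(Cl)cc2)n1` is not yet measured; it differs from compound 1 by hydrogen in place of ethyl on a saturated chain carbon bound to an oxygen next to a carbonyl group. Among the compounds with values here, with no comparable step on record, a step of a 1.2-fold lower number from compound 1 to compound 4 (0.08 log units; within the scatter) is expected in this assay, not beyond the scatter in either direction. Compound 4 is expected to give 4000 nM in this assay, within 1500 nM to 12000 nM.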

Compound 4, half-maximal inhibitory concentration: 5920 nM
Compound 4: the middle estimate sits 1.5-fold (0.17 log units) below what was measured; measured number inside the range.
By their numbers in this assay, from the lowest: compounds 1, 4 and 3 (each within the scatter of the next, the first and the last beyond it); then compound 2.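

In this assay, within the data shown here, the first single-place change on record gives a 1.2-fold higher number from compound 1 to compound 4 (0.09 log units; within the scatter) and so propyl to methyl on this ester does not separate the two compounds. At this place, the propoxycarbonyl group of compound 1 can give way to methoxycarbonyl without a change that can be told from the scatter. No measured property on record bears on this step. Open, from the compounds shown here alone, is whether a carboxylic acid, an amide or a longer chain such as octyl at this place would shift the number. Also open, going by these compounds, is whether the other propoxycarbonyl group of compound 4 can be trimmed in the same way.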